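This account rests on a few compounds, and the source may have more. Where it says the series, first, only, none or still open, it means among the compounds named here.

Three amides built on one shared core have been measured in an assay on isolated protein for inhibition of Rho-associated protein kinase 1 (Homo sapiens), read by scintillation counting, radiometric assay and 33P incorporation, with a stated time of 40 min, in the presence of a further agent that is not named here; on this read-out lower numbers stand for stronger inhibition and higher numbers for weaker inhibition. Compound 1 `Cc1ccc(C(=O)Nc2cccc(NC(=O)COc3ccc4c(=O)ccoc4c3)c2)cc1` gives 183 nM, compound 2 `CC(C)(C)c1ccc(C(=O)Nc2cccc(NC(=O)COc3ccc4c(=O)ccoc4c3)c2)cc1` gives 165 nM, and compound 3 `O=C(COc1ccc2c(=O)ccoc2c1)Nc1cccc(NC(=O)c2cccc([N+](=O)[O-])c2)c1` gives 528 nM, the highest of the three numbers. The step of a 1.1-fold lower number from compound 1 to compound 2 (0.04 log units; within the scatter) lies within the scatter, whereas a 2.9-fold higher number from compound 1 to compound 3 (0.46 log units; beyond the scatter) and a 3.2-fold higher number from compound 2 to compound 3 (0.51 log units; beyond the scatter) lie beyond it. Compound 4 `O=C(COc1ccc2c(=O)ccoc2c1)Nc1cccc(NC(=O)c2cnc(C(F)(F)F)s2)c1` differs from compound 3 in one place: 2-(trifluoromethyl)-1,3-thiazol-5-yl in place of 3-nitrophenyl on a carbonyl carbon. Within the data shown here, no measured step exchanges the aryl group on the carbonyl carbon for a heteroaryl one; the two steps that bear on the change show only modest movement in this assay when that group is varied. Compound 4 is therefore expected near 400 nM, between 150 nM and 1100 nM. The estimated step of a 1.3-fold lower number from compound 3 to compound 4 (0.12 log units; within the scatter) is expected to stay within the scatter.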

Compound 4, half-maximal inhibitory concentration: 160 nM
For compound 4 the middle estimate is 2.5-fold (0.40 log units) above the measured one; low and high end bracket the measured number.
By their numbers in this assay, from the lowest: compounds 4, 2 and 1 (each within the scatter of the next); then compound 3.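

Placing 2-(trifluoromethyl)-1,3-thiazol-5-yl on this carbonyl carbon in place of 3-nitrophenyl gives a 3.3-fold lower number from compound 3 to compound 4 (0.52 log units; beyond the scatter), the first heteroaryl group seen at this position. Against the phenyl amides, a 1.0-fold lower number from compound 2 to compound 4 (0.01 log units; within the scatter) and a 1.1-fold lower number from compound 1 to compound 4 (0.06 log units; within the scatter), so a five-membered aromatic ring with 2 hetero atoms serves here as well as 4-methylphenyl or 4-(tert-butyl)phenyl. No measurement shown explains this result. The compounds shown leave open what the trifluoromethyl itself contributes, and whether an amine or a carboxylic acid in its place on the five-membered ring would hold the number.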